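A few compounds are considered here, and "the series" means these few. Any claim that something is new, unique, unknown or untested is made for them only; others in the source may bear on it.

Compound 1 `Oc1ccc(NC(=S)Nc2ccc3[nH]ccc3c2)cc1`: "not active" (no number reported)
Compound 2 `OCc1ccc(NC(=S)Nc2ccc3[nH]ccc3c2)cc1`: "not active" (no number reported)
Compound 3 `COc1ccc(NC(=S)Nc2ccc3[nH]ccc3c2)cc1`: 36000 nM

Of the compounds shown here, three built on the same core have been tested in an ADME assay on cells for inhibition of Amine oxidase [flavin-containing] A (Homo sapiens), read by spectrophotometry; a lower number here means a stronger inhibitor, a higher number a weaker inhibitor. Compound 1 gives "not active" (no number reported) and compound 2 gives "not active" (no number reported), so neither of them yields a number. Going by the values given here, compound 3 is the only one with a measured figure, 36000 nM, and that figure is a high one, which means compound 3 is a weak inhibitor; it stands alone simply as the single entry with a number. Compounds 1 and 2 carry no number. Among the compounds with values here, no step between two measured compounds can be drawn from these data.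

Compound 4 `S=C(Nc1ccc(Br)cc1)Nc1ccc2[nH]ccc2c1` differs from compound 3 in one place: bromo in place of methoxy on an aromatic carbon. Within the data shown here, with no measured step to build on, only a modest shift is expected, of the size a 1.8-fold lower number from compound 3 to compound 4 (0.26 log units; within the scatter), toward slightly stronger inhibition. The expected value for compound 4 in this assay is 20000 nM, with a range from 5000 nM to 80000 nM.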

Compound 4, half-maximal inhibitory concentration: 5900 nM
The estimate for compound 4 lay 3.4-fold (0.53 log units) above the measured number, and the stated range covers the measured number.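

In this assay, bromo in place of methoxy on the aromatic carbon para to a large group gives a 6.1-fold lower number from compound 3 to compound 4 (0.79 log units; beyond the scatter). Going by these compounds alone, this is the first measured sign that the group at this place can change the strength of inhibition by more than the usual scatter of the assay. The change swaps a methoxy group, which counts as a hydrogen-bond acceptor, for a bromo group, which does not, but nothing measured here explains why the number falls.

A single step cannot show whether other groups at this place, such as chloro, an amine or a carboxylic acid, would give a lower or a higher number. From the compounds shown here alone, compounds 1 and 2 carry no number, so steps involving them cannot be read, and the effect of changes elsewhere on the shared core remains unknown.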